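Replacing dichlorophenyl with phenyl on a chalcone scaffold

A few compounds are considered here, and "the series" means these few. Any claim that something is new, unique, unknown or untested is made for them only; others in the source may bear on it.

Measured compounds:
- compound 1, `CC1(C)Cc2c(OCc3ccccc3)ccc(C(=O)/C=C/c3ccccc3)c2O1`: 30300 nM
- compound 2, `CC1(C)Cc2c(ccc(C(=O)/C=C/c3ccc(Cl)cc3Cl)c2OCc2ccccc2)O1`: > 100000 nM
- compound 3, `CC1(C)Cc2c(OCc3ccccc3)ccc(C(=O)/C=C/c3cn(-c4ccccc4)nc3-c3ccc([N+](=O)[O-])cc3)c2O1`: > 100000 nM

All three compounds were tested in a functional assay on B16 cells (Mus musculus) for antiproliferative activity, read by MTT assay, with a stated time of 48 h; on this read-out lower numbers stand for stronger inhibition and higher numbers for weaker inhibition. Compound 1 gives 30300 nM in this assay. Compound 2 does not reach a number in this assay; its result is the limit > 100000 nM. Compound 3 likewise sits at the limit > 100000 nM in this assay. So compound 2 stands at the weak end of what is shown, together with compound 3, and the only numbered value belongs to compound 1, as stated in the limit of > 100000 nM in this assay, at which 2 of the 3 values shown sit.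

Compound 4, `CC1(C)Cc2c(ccc(C(=O)/C=C/c3ccccc3)c2OCc2ccccc2)O1`, has not yet been measured. It differs from compound 2 in one place: phenyl in place of 2,4-dichlorophenyl on a double-bonded chain carbon bound to a double-bonded chain carbon. Because compound 2 sits at the limit > 100000 nM, the size of the step can only be guessed from one side. The expected step of an at least 2.2-fold lower number from compound 2 to compound 4 (0.34 log units; beyond the scatter) points toward somewhat stronger inhibition, though a result at the limit remains possible. Compound 4 is therefore expected to give about 45000 nM in this assay, within the range 12000 nM to 150000 nM.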

Compound 4, half-maximal inhibitory concentration: > 100000 nM
Compound 4: no number, only a limit (the forecaster's own chance of this, stated with the estimate: 35%); at least 2.2-fold (0.34 log units) between middle value and limit.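

In this assay compound 4 reaches only a limit, > 100000 nM. Compound 2 also sits at a limit, so no step can be read between compound 2 and compound 4. The compounds shown leave open whether phenyl and 2,4-dichlorophenyl differ at all in inhibition.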